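Pyridin-3-yl in place of pyridin-2-yl: working notes

The source may hold more compounds than are shown below. What is called first, only, known or untested is meant among the compounds shown, and "the series" means these compounds.

Measured so far in a functional assay on colon cells (Homo sapiens) for antiproliferative activity (on this read-out higher numbers stand for weaker inhibition of growth and lower numbers for stronger inhibition of growth), on this series:
- compound 1 `Cc1sc2nc(-c3ccncc3)c(/C=N/NC(=N)N)n2c1C` (79400 nM)
- compound 2 `Cc1cn2c(/C=N/NC(=N)N)c(-c3cccnc3)nc2s1` (20900 nM)
- compound 3 `N=C(N)N/N=C/c1c(-c2ccccn2)nc2sc(Cl)cn12` (15100 nM)

Compound 3 lies within the scatter of compound 2. Compound 1 has a higher number than compound 3, with a gap beyond the scatter.

The next compound is compound 4 `N=C(N)N/N=C/c1c(-c2cccnc2)nc2sc(Cl)cn12`, which has pyridin-3-yl in place of pyridin-2-yl on an aromatic carbon of the shared core (pyridin-3-yl in place of pyridin-2-yl on an aromatic carbon). Within the data shown here, no two measured compounds differ in one place only, so the series gives no direct size for this change. Compound 2 also carries pyridin-3-yl, and its value (20900 nM) is within the scatter of compound 3. On that basis, no change beyond the scatter is expected in this assay. The expected step is a 1.1-fold higher number from compound 3 to compound 4 (0.05 log units; within the scatter) and it has no firm direction. For compound 4 the estimated value is 17000 nM, with an expected range from 7000 nM to 42000 nM.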

Compound 4, concentration for total growth inhibition: 21900 nM
Compound 4: middle estimate off by 1.3-fold (0.11 log units), on the low side; the measured number falls inside the stated range.
By their numbers in this assay, from the lowest: compounds 3, 2 and 4 (each within the scatter of the next); then compound 1.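

In this assay, pyridin-3-yl in place of pyridin-2-yl on an aromatic carbon of the shared core gives a 1.5-fold higher number from compound 3 to compound 4 (0.16 log units; within the scatter), the first direct size for this change at this position. With chloro held constant, these two pyridine attachments are therefore not told apart on this read-out. Chloro in place of methyl on an aromatic carbon, with pyridin-3-yl held constant, gives a 1.0-fold higher number from compound 2 to compound 4 (0.02 log units; within the scatter), so that single-place change is not resolved either in this pair.

Still open, as far as these compounds go, is whether phenyl or an amine on the same aromatic carbon of the core would give a step beyond the scatter. No measurement is available that could explain why these two steps are so small.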